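This account rests on a few compounds, and the source may have more. Where it says the series, first, only, none or still open, it means among the compounds named here.

Measured so far:
compound 1, `Cc1ccc(N2CCN(c3ccc(C(=O)/C=C/c4ccccc4)cc3)CC2)c(C)c1`, which in a functional assay on the whole organism (strain Kunming) for inhibition, with Mus musculus as the target, with a stated time of 1 h, at a dose of 40 mg/kg by the oral route (a higher number here means more inhibition at the dose given (going by the name of the read-out), a lower number less inhibition), gives 15%;
compound 2, `COc1ccc(N2CCN(c3ccc(C(=O)/C=C/c4ccc(Cl)cc4)cc3)CC2)cc1`, which in this assay gives 55.1%.

Of the two, compound 2 stands higher, and its distance from compound 1 lies beyond the usual scatter of the measurement. Compound 3, `O=C(/C=C/c1ccc(Cl)cc1)c1ccc(N2CCN(S(=O)(=O)c3ccc(Cl)cc3)CC2)cc1`, has not yet been measured in this assay. It departs from compound 2 in one place: (4-chlorophenyl)sulfonyl in place of 4-methoxyphenyl on an amine nitrogen in a ring. Among the measured compounds shown here, no measured pair shows this kind of change, so the size of the step cannot be read from the numbers at hand; what is known is only that the two measured compounds sit far apart and that the change in compound 3 is a different one from the change between them. The step from compound 2 to compound 3 in this assay is expected to be modest and downward, of about a number 15.1 percentage points lower from compound 2 to compound 3 (beyond the scatter). For compound 3 the estimated inhibition is 40%, within a range from 15% to 65%.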

Compound 3, a percentage reported as inhibition, in the whole organism at one dose (the size of the read-out at that dose, not a potency): 56.6%
For compound 3 the middle estimate is 16.6 percentage points below the measured one; the range from low to high includes it.
By their numbers in this assay, from the lowest: compound 1; then compounds 2 and 3 (each within the scatter of the next).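

In this assay, putting (4-chlorophenyl)sulfonyl in place of 4-methoxyphenyl on an amine nitrogen in a ring gives a number 1.5 percentage points higher from compound 2 to compound 3 (within the scatter), so the two compounds cannot be told apart in this read-out. Among the compounds shown here, this nitrogen, until now seen only with an aromatic ring attached directly, thus also carries a sulfonyl-linked aromatic ring with the inhibition kept at the level of compound 2. Nothing at hand bears on why the two groups read alike.

The change alters the link to the aromatic ring and the group on that ring at once, and the compounds shown do not separate the two. Also open, on these data alone, is how this nitrogen fares with a plain phenylsulfonyl, a methanesulfonyl, an acetyl or a bare hydrogen.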